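Methyl to butyl on compound 2

The source may report more compounds than this note shows. Statements on the series, on what has been measured and on what is new or still open speak of the compounds shown alone.

Among the compounds with values here, compound 1 `O=c1ccocc1O` and compound 2 `Cc1cc(=O)c(O)c(C)o1` are the only measured members so far. In an ADME assay for lipophilicity (on this read-out lower numbers stand for lower lipophilicity and higher numbers for higher lipophilicity), compound 1 gives -0.92 and compound 2 gives 0.44 as the higher of the two numbers, and the gap between them lies beyond the scatter. Compound 3 `CCCCc1oc(C)cc(=O)c1O` awaits measurement. It differs from compound 2 by propyl in place of hydrogen on a saturated chain carbon bound to an aromatic carbon. Within the data shown here, no step between measured compounds that differ in one place is available, and the expectation rests on the structural change alone. A rise well beyond the scatter in this assay is expected, with a number 1.31 log units higher from compound 2 to compound 3 (beyond the scatter) as the estimated step. For compound 3 the expected value is 1.75 with an estimated range from 1.25 to 2.25 on this read-out.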

Compound 3, distribution coefficient: 1.92
Beside the measured number, compound 3's estimate is 0.17 log units below it, and the stated range covers the measured number.
By their numbers in this assay, from the lowest: compound 1; then compound 2; then compound 3.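

Within the data shown here, the first step between compounds that differ in one place shows that, in this assay, propyl in place of hydrogen on a saturated chain carbon bound to an aromatic carbon gives a number 1.48 log units higher from compound 2 to compound 3 (beyond the scatter). The methyl to butyl change at this position thus has a measured size, but as a single step it defines no trend with chain length. Nothing available bears on the reason for the size of this step.

On these data alone, how the number moves across chain lengths remains open, and an ethyl or a hexyl group at this position would bear on that. Also open, as far as these compounds go, is what a butyl chain ending in an amine or a carboxylic acid would give in this assay.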